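Adding a third methoxy: what compound 3 is expected to show

A few compounds are considered here, and "the series" means these few. Any claim that something is new, unique, unknown or untested is made for them only; others in the source may bear on it.

Measured so far:
compound 1 `COc1ccc(C(=O)/C=C/c2cc(-c3cc(OC)c(OC)c(OC)c3)n[nH]2)cc1OC`: 103%
compound 2 `COc1ccc(C(=O)/C=C/c2cc(-c3cc(OC)c(OC)c(OC)c3)n[nH]2)cc1`: 103%

In a functional assay on NCI-H460 cells (Homo sapiens) for cytotoxicity, read by sulforhodamine B assay, with a stated time of 48 h, tested at 0.01 uM (a higher number here means a weaker effect of the compound at the concentration tested, a lower number a stronger effect), compound 1 gives 103% and compound 2 gives 103%. The step of no change at the digits printed from compound 1 to compound 2 (within the scatter) lies within the scatter, so compound 1 stands level with compound 2. Compound 3 `COc1cc(C(=O)/C=C/c2cc(-c3cc(OC)c(OC)c(OC)c3)n[nH]2)cc(OC)c1OC` differs from compound 1 by methoxy in place of hydrogen on an aromatic carbon. Among the measured compounds shown here, the only measured step, hydrogen in place of methoxy on an aromatic carbon, left this assay unchanged within the scatter; the present change, methoxy in place of hydrogen on an aromatic carbon, is the same kind of change in the other direction. No step beyond the scatter is therefore expected, no change at the digits printed from compound 1 to compound 3 (within the scatter). Compound 3 is estimated at 103%, within 93% to 113%.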

Compound 3, a percentage reported as activity, at one concentration (the size of the read-out at that concentration, not a potency): 102%
For compound 3 the middle estimate is 1 percentage points above the measured one, and the stated range covers the measured number.
By their numbers in this assay, from the lowest: compounds 3, 1 and 2 (each within the scatter of the next).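

In this assay, methoxy in place of hydrogen on the aromatic carbon meta to a large group gives a number 1 percentage points lower from compound 1 to compound 3 (within the scatter). With the earlier step, no change at the digits printed from compound 1 to compound 2 (within the scatter), methoxy has now been both removed from and added to compound 1, and neither change leaves the scatter. No measured evidence bears on the reason for this flat result. Going by these compounds, whether a hydroxyl or an amine on this carbon would move the read-out beyond the scatter stays open. So does whether these methoxy changes would register at another concentration.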